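Extending a Guanidine Linker: Expected Cytotoxicity of Compound 3

A few compounds are considered here, and "the series" means these few. Any claim that something is new, unique, unknown or untested is made for them only; others in the source may bear on it.

Measured so far:
compound 1 `CCN(CC)CC[n+]1c(SCC(=O)NCCCNC(=N)N)[nH]c2c(C)nc(N(CC)CC)nc21`: > 100 uM
compound 2 `CCN(CC)c1nc(C)c2[nH]c(SCC(=O)NCCNC(=N)N)[n+](CCCN(C)C)c2n1`: > 100 uM

In an ADME assay on CEM174 cells (Homo sapiens) for cytotoxicity (on this read-out lower numbers stand for higher toxicity in this test and higher numbers for lower toxicity in this test), compound 2 gives > 100 uM, which is a limit of the assay rather than a number. Compound 1 gives > 100 uM in this assay, also a limit. Compound 2 thus stands at the limit of > 100 uM in this assay, at which 2 of the 2 values shown sit. Compound 3 `CCN(CC)c1nc(C)c2[nH]c(SCC(=O)NCCCNC(=N)N)[n+](CCCN(C)C)c2n1` differs from compound 2 by a group of 5 heavy atoms (2 carbon, 3 nitrogen; no ring) in place of a group of 4 heavy atoms (1 carbon, 3 nitrogen; no ring), on a saturated chain carbon, two bonds along the chain from an amide-type nitrogen. No measured step of this kind exists among these compounds. Compound 3 is expected to show no step beyond the scatter, a step that the limit leaves unreadable from compound 2 to compound 3, with the assay again likely reporting only a limit. The estimate for compound 3 in this assay is 150 uM, between 80 uM and 400 uM.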

Compound 3, half-maximal toxic concentration: > 100 uM
Compound 3 ended at the assay's limit; the forecaster's own chance of this, stated with the estimate: 85%; the middle value does not contradict the limit.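

Within the data shown here, compound 1, compound 2 and compound 3 all end at a limit of the assay, so no step among them can be read. The compounds shown leave open where real toxic concentrations lie in this assay: the limit of > 100 uM in this assay, at which 3 of the 3 values shown sit.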